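Series notes: aryl swap on the core of compound 1

This account rests on a few compounds, and the source may have more. Where it says the series, first, only, none or still open, it means among the compounds named here.

Measured so far:
- compound 1 `C=CCn1c(=O)/c(=C\c2cc(Br)ccc2F)[nH]c(=O)/c1=C\c1ccccc1OC`: 5100 nM
- compound 2 `COc1ccccc1/C=c1\c(=O)[nH]/c(=C/c2cccc(Cl)c2Cl)c(=O)n1C`: 110 nM
- compound 3 `C=CCn1c(=O)/c(=C\c2cccc(Br)c2)[nH]c(=O)/c1=C\c1cccc(Br)c1`: "not active" (no number reported), without a number

Compound 1 holds the highest of the two numbers in a functional assay on K562 cells (Homo sapiens) for cytotoxicity, read by CCK-8 assay, with a stated time of 72 h; on this read-out higher numbers stand for weaker inhibition and lower numbers for stronger inhibition. Its nearest neighbour, compound 2, gives 110 nM, a gap beyond the scatter, while compound 3 stands apart, reported as "not active" (no number reported) with no number. Within the data shown here, no pair among the measured compounds differs in one place only, so no single-change step is available.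

Compound 4 `C=CCn1c(=O)/c(=C\c2cccc(C)c2)[nH]c(=O)/c1=C\c1ccccc1OC` differs from compound 1 by 3-methylphenyl in place of 5-bromo-2-fluorophenyl on a double-bonded chain carbon bound to an aromatic carbon. Nothing measured isolates this change; compound 2 and compound 3 each differ from compound 1 at more than one place. The expectation is therefore anchored on compound 1 and its value 5100 nM, with a wide band. The step from compound 1 to compound 4 is expected to be small, a 1.1-fold lower number from compound 1 to compound 4 (0.05 log units; within the scatter), not clearly beyond the scatter in either direction. Compound 4 is estimated at 4500 nM, within 1200 nM to 18000 nM in this assay.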

Compound 4, half-maximal inhibitory concentration: 8800 nM
Compound 4: middle estimate off by 2.0-fold (0.29 log units), on the low side, within the range that was stated.
By their numbers in this assay, from the lowest: compound 2; then compounds 1 and 4 (each within the scatter of the next).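

In this assay the step of a 1.7-fold higher number from compound 1 to compound 4 (0.24 log units; within the scatter) comes with 3-methylphenyl in place of 5-bromo-2-fluorophenyl on a double-bonded chain carbon bound to an aromatic carbon. Among these compounds, this is the first single-place comparison: with the rest of the core of compound 1 held fixed, this position takes an aryl group with a methyl and no halogen, with no shift beyond the scatter. Neither the bromine nor the fluorine is therefore required here to keep the reading at the level of compound 1, and no measurement at hand speaks to the reason for this outcome.

Going by these compounds, whether an amine or a carboxylic acid in place of this aryl group would give a step beyond the scatter stays open. This single step also cannot separate any contribution of the bromine from that of the fluorine.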